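The source may hold more compounds than are shown below. What is called first, only, known or untested is meant among the compounds shown, and "the series" means these compounds.

Compound 3 `O=C(Nc1cccc2cccnc12)N1CCC(c2nc(-c3ccc4ccccc4n3)no2)CC1` gives 1400 nM in a functional assay on Shh Light II cells (Mus musculus) for inhibition, read by a luciferase reporter (on this read-out higher numbers stand for weaker inhibition and lower numbers for stronger inhibition), the highest of the three numbers recorded, while compound 1 `O=C(NC1CC[S+]([O-])CC1)N1CCC(c2nc(-c3ccc4ccccc4n3)no2)CC1` gives 850 nM and compound 2 `CC(=O)N1CCC(NC(=O)N2CCC(c3nc(-c4ccc5ccccc5n4)no3)CC2)CC1` gives 500 nM. All three measured steps change the group on the amide-type nitrogen: a 1.7-fold lower number from compound 1 to compound 2 (0.23 log units; within the scatter), a 1.6-fold higher number from compound 1 to compound 3 (0.22 log units; within the scatter) and a 2.8-fold higher number from compound 2 to compound 3 (0.45 log units; beyond the scatter). Compound 4 `O=C(N1CCC(c2nc(-c3ccc4ccccc4n3)no2)CC1)N1CCCc2ccccc21` differs from compound 3 in that (1,2,3,4-tetrahydroquinolin-1-yl in place of (quinolin-8-yl)amino on a carbonyl carbon). Among the compounds with values here, none of the measured steps removes the amino linkage itself, so they show only that varying this end of the molecule has shifted this assay by small to modest amounts. Compound 4 is therefore expected to give no step beyond the scatter, a 1.1-fold lower number from compound 3 to compound 4 (0.03 log units; within the scatter). Compound 4 is estimated at 1300 nM in this assay, with a range from 450 nM to 4000 nM.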

Compound 4, half-maximal inhibitory concentration: 2300 nM
Estimate against measurement, compound 4: 1.8-fold (0.25 log units) below; the range from low to high includes it.
By their numbers in this assay, from the lowest: compounds 2, 1, 3 and 4 (each within the scatter of the next, the first and the last beyond it).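

In this assay, putting 1,2,3,4-tetrahydroquinolin-1-yl on the carbonyl carbon removes the hydrogen-bond donor of (quinolin-8-yl)amino and gives a 1.6-fold higher number from compound 3 to compound 4 (0.22 log units; within the scatter), so the amide hydrogen of compound 3 is not needed to keep this level of inhibition. The same group gives a 4.6-fold higher number from compound 2 to compound 4 (0.66 log units; beyond the scatter) and a 2.7-fold higher number from compound 1 to compound 4 (0.43 log units; beyond the scatter), and the second of these steps is beyond the scatter, unlike the step from compound 1 to compound 3. No measured evidence accounts for these steps. The compounds shown leave open whether morpholin-4-yl or 4-acetylpiperazin-1-yl on this carbonyl carbon, also without the amide hydrogen, would reach the level of compound 2.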